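Nitrofuran amides: tert-butyl on the aryl ring of compound 2

The source may report more compounds than this note shows. Statements on the series, on what has been measured and on what is new or still open speak of the compounds shown alone.

Compound 2 `CC(C)(NC(=O)c1ccc([N+](=O)[O-])o1)c1ccccc1` has been run in an ADME assay on Vero cells (Chlorocebus sabaeus) for cytotoxicity, read by MTT assay, with a stated time of 48 h (a lower number here means that less compound is tolerated, a higher number that more compound is tolerated), and its result is a limit of the assay rather than a number: compound 2 gives > 180000 nM. For comparison, compound 1 `CC(NC(=O)c1ccc([N+](=O)[O-])o1)c1ccccc1` gives 24000 nM in this assay, and compound 3 `O=C(NC1(c2ccccc2)CC1)c1ccc([N+](=O)[O-])o1` gives 46000 nM. Among the measured compounds shown here, the single measured step that ends at compound 2 is an at least 7.5-fold higher number from compound 1 to compound 2 (0.87 log units; beyond the scatter), and its size is bounded only by the limit of > 180000 nM in this assay, at which 1 of the 3 values shown sits.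

Compound 4 `CC(C)(C)c1ccc(C(C)(C)NC(=O)c2ccc([N+](=O)[O-])o2)cc1` awaits measurement in this assay. Relative to compound 2 the change is tert-butyl in place of hydrogen on an aromatic carbon. For the measured compounds named here, none of the measured steps touches the six-membered aromatic ring, so no step bears directly on this change; the only anchor is that compound 2 already sits at the limit. With nothing pointing either way, no step beyond the scatter is expected, though a return below the limit cannot be excluded. The expected step from compound 2 to compound 4 is an at least 1.2-fold lower number from compound 2 to compound 4 (0.07 log units; that floor lies within the scatter). Compound 4 is thus estimated at 150000 nM, within a range of 50000 nM to 400000 nM.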

Compound 4, half-maximal cytotoxic concentration: > 150000 nM
Compound 4: only a limit was reported; the forecaster's own chance of this, stated with the estimate: 50%; the middle value lies on the limit itself.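

In this assay compound 4 gives > 150000 nM, a limit. Among the compounds shown here, compound 2 gives > 180000 nM, also a limit, and no step between compound 2 and compound 4 can be read. The compounds shown leave open whether tert-butyl in place of hydrogen on an aromatic carbon changes this number at all.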